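Compound 4: 4-chlorophenyl in place of 3-chlorophenyl

The source may report more compounds than this note shows. Statements on the series, on what has been measured and on what is new or still open speak of the compounds shown alone.

Three compounds of the series carry numbers in a functional assay on L1210 cells (Mus musculus) for inhibition, read by MTT assay, with a stated time of 72 h; a lower number here means a stronger inhibitor, a higher number a weaker inhibitor. Compound 1 `COc1cc(NC(C)CCCNC(=O)NNC(=O)Nc2cccc(F)c2)c2ncccc2c1` gives 108000 nM. Compound 2 `COc1cc(NC(C)CCCNC(=O)Nc2ccc(O)cc2)c2ncccc2c1` gives 21000 nM. Compound 3 `COc1cc(NC(C)CCCNC(=O)NNC(=O)Nc2cccc(Cl)c2)c2ncccc2c1` gives 27000 nM. The measured steps are a 5.1-fold lower number from compound 1 to compound 2 (0.71 log units; beyond the scatter), a 4.0-fold lower number from compound 1 to compound 3 (0.60 log units; beyond the scatter) and a 1.3-fold higher number from compound 2 to compound 3 (0.11 log units; within the scatter). Compound 3 stands second highest of the three numbers; its nearest neighbour is compound 2, within the scatter, and its furthest is compound 1, beyond the scatter.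

Compound 4 `COc1cc(NC(C)CCCNC(=O)NNC(=O)Nc2ccc(Cl)cc2)c2ncccc2c1` differs from compound 3 in one place: 4-chlorophenyl in place of 3-chlorophenyl on an amide-type nitrogen. Within the data shown here, no measured pair differs only in the placement of chloro on the phenyl, so no step bears directly on this change. The step of a 4.0-fold lower number from compound 1 to compound 3 (0.60 log units; beyond the scatter) exchanged one halogen for another on an aromatic carbon, and the steps of a 5.1-fold lower number from compound 1 to compound 2 (0.71 log units; beyond the scatter) and a 1.3-fold higher number from compound 2 to compound 3 (0.11 log units; within the scatter) replaced the whole group on the amide-type nitrogen; neither kind of change tells how the series reads a move of chloro within the ring. With nothing to lean on, no step beyond the scatter is expected in this assay in either direction. The estimate for compound 4 is 27000 nM, with a range of 9000 nM to 80000 nM. The expected step is no change at the digits printed from compound 3 to compound 4 (within the scatter), within the scatter.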

Compound 4, half-maximal inhibitory concentration: 58000 nM
Compound 4: middle estimate off by 2.1-fold (0.33 log units), on the low side; measured number inside the range.
By their numbers in this assay, from the lowest: compounds 2 and 3 (each within the scatter of the next); then compounds 4 and 1 (each within the scatter of the next).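

In this assay, moving chloro within the phenyl on the amide-type nitrogen registers in the read-out (a 2.1-fold higher number from compound 3 to compound 4 (0.33 log units; beyond the scatter)), so 3-chlorophenyl and 4-chlorophenyl are told apart at this place, which the earlier exchanges of halogen and of the whole group could not show. The other two comparisons also shift: compound 3 stood within the scatter of compound 2, whereas 4-chlorophenyl gives a step beyond it (a 2.8-fold higher number from compound 2 to compound 4 (0.44 log units; beyond the scatter)), and 3-fluorophenyl and 4-chlorophenyl are not separated (a 1.9-fold lower number from compound 1 to compound 4 (0.27 log units; within the scatter)), although 3-fluorophenyl and 3-chlorophenyl were. No measurement on hand accounts for the difference between the two placements of chloro.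

As far as these compounds go, with one pair, it remains open whether the preference for 3-chlorophenyl over 4-chlorophenyl extends to other substituents, and 3-fluorophenyl set against 4-fluorophenyl would test this directly. Unsubstituted phenyl at the same place would also show whether chloro at either placement changes the number at all, and whether the gap between compound 3 and compound 4 comes from one placement or from both.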